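The source may report more compounds than this note shows. Statements on the series, on what has been measured and on what is new or still open speak of the compounds shown alone.

Compound 1 `Cc1ccc2oc(-c3ccc(NC(=O)CN4CCN(CCCN(C)C)CC4)cc3)nc2c1`: 3160 nM in a functional assay on HepG2 cells (Homo sapiens) for cytotoxicity, read by MTT assay, with a stated time of 24 h; a lower number here means a stronger inhibitor, a higher number a weaker inhibitor
Compound 2 `Cc1ccc2oc(-c3ccc(NC(=O)CN4CCN(CCCN(C)C)CC4)c(C)c3)nc2c1`: 5650 nM
Compound 3 `Cc1cc(-c2nc3cc(Cl)ccc3o2)ccc1NC(=O)CCl`: 35000 nM

Compound 1 shows the lowest number of the three in this assay; compound 2 sits within the scatter of it, while compound 3 lies well beyond the scatter, giving a far higher number. Compound 4 `CN(C)CCCN1CCN(CC(=O)Nc2ccc(-c3nc4cc(Cl)ccc4o3)cc2)CC1` differs from compound 1 by chloro in place of methyl on an aromatic carbon. For the measured compounds named here, only one single-change step has been measured, a 1.8-fold higher number from compound 1 to compound 2 (0.25 log units; within the scatter), and it concerns a methyl on a different ring, so it bears on the present change only loosely. Compound 3 carries the same chloro group as compound 4 but differs from compound 1 in several further places, so its value cannot fix the step on its own. The expectation is therefore a step of a 1.2-fold higher number from compound 1 to compound 4 (0.08 log units; within the scatter), with nothing beyond the scatter. Compound 4 is estimated at 3800 nM, with a range from 1500 nM to 10000 nM.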

Compound 4, half-maximal inhibitory concentration: 1250 nM
Compound 4: middle estimate off by 3.0-fold (0.48 log units), on the high side; measured number outside the range, below it.
By their numbers in this assay, from the lowest: compound 4; then compounds 1 and 2 (each within the scatter of the next); then compound 3.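

In this assay chloro in place of methyl on this aromatic carbon gives a 2.5-fold lower number from compound 1 to compound 4 (0.40 log units; beyond the scatter) and so shows that this position responds, if modestly, to a swap of one heavy atom. The only earlier single change, on a different ring, gave a 1.8-fold higher number from compound 1 to compound 2 (0.25 log units; within the scatter) and so this is the first single change shown to move the number beyond the scatter. Nothing measured here gives a reason for the step.

As far as these compounds go, whether hydrogen, fluoro or methoxy at this position would give a lower or higher number stays open. Also open, from the compounds shown here alone, is whether chloro would have the same effect alongside the added methyl of compound 2.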